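The compounds below may be only part of what the source reports. "The series", "measured", "known", "first", "only" and "open" are said of these compounds alone.

Compound 3, `CC(C)C(Cc1noc(=O)[nH]1)c1ccc(-c2ccc3cccc(F)c3c2)[nH]c1=O`, gives 34 nM in an assay on CHO cells for displacement of a labelled ligand from prostaglandin E2 receptor EP3 subtype (Homo sapiens), read by radioligand binding; a lower number here means a stronger inhibitor, a higher number a weaker inhibitor. Among the three compounds measured there, it carries the highest number: compound 1, `CC(C)C(Nc1nnc[nH]1)c1ccc(-c2ccc3cccc(F)c3c2)[nH]c1=O`, gives 22 nM in this assay, a gap that stays within the scatter, while compound 2, `CC(C)C(c1ccc(-c2ccc3cccc(F)c3c2)[nH]c1=O)N1CCCCC1=O`, gives 6.4 nM, which lies beyond it.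

The step to compound 4, `CC(C)C(c1ccc(-c2ccc3cccc(F)c3c2)[nH]c1=O)N1CCNC1=O`, is a group of 6 heavy atoms (3 carbon, 2 nitrogen, 1 oxygen; one five-membered non-aromatic ring with 2 hetero atoms) in place of a group of 7 heavy atoms (3 carbon, 2 nitrogen, 2 oxygen; one five-membered aromatic ring with 3 hetero atoms), on a saturated chain carbon bound to an aromatic carbon and a saturated chain carbon. The measured steps that bear on it are those involving a ring on that same carbon. The step from compound 2 to compound 3 showed a 5.3-fold higher number from compound 2 to compound 3 (0.73 log units; beyond the scatter), so exchanging a six-membered non-aromatic ring with one hetero atom for the five-membered aromatic ring cost potency. The step from compound 1 to compound 2 showed a 3.4-fold lower number from compound 1 to compound 2 (0.54 log units; beyond the scatter), and the step from compound 1 to compound 3 showed a 1.5-fold higher number from compound 1 to compound 3 (0.19 log units; within the scatter). For the measured compounds named here, compound 4 brings back a non-aromatic ring attached through nitrogen and bearing a carbonyl, which resembles the group in compound 2 more than the one in compound 3, so a lower number is expected, of a size near a 3.4-fold lower number from compound 3 to compound 4 (0.53 log units; beyond the scatter), though how far the five-membered ring with its second nitrogen matches the six-membered ring of compound 2 is not known from these data. Compound 4 is therefore estimated at 10 nM in this assay, within a range of 4 nM to 30 nM.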

Compound 4, inhibition constant: 9.1 nM
Beside the measured number, compound 4's estimate is 1.1-fold (0.04 log units) above it, within the range that was stated.
By their numbers in this assay, from the lowest: compounds 2 and 4 (each within the scatter of the next); then compounds 1 and 3 (each within the scatter of the next).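

At the saturated chain carbon bound to an aromatic carbon and a saturated chain carbon, a second non-aromatic ring bearing a carbonyl now gives a low number in this assay, with a 3.7-fold lower number from compound 3 to compound 4 (0.57 log units; beyond the scatter) and a 2.4-fold lower number from compound 1 to compound 4 (0.38 log units; beyond the scatter) showing that the result for compound 2 is not a single case. Changing 2-oxopiperidin-1-yl to 2-oxoimidazolidin-1-yl alters the ring size and the count of ring hetero atoms at once, yet a 1.4-fold higher number from compound 2 to compound 4 (0.15 log units; within the scatter) stays within the scatter, so this assay does not separate the two rings. The four compounds now fall into two sets, with compounds 2 and 4 each lower beyond the scatter than compounds 1 and 3, which carry five-membered aromatic rings, but nothing measured here explains that split.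

On these data alone, whether the low numbers depend on the ring carbonyl remains open, as a plain piperidin-1-yl group would test this directly. As far as these compounds go, it is also open whether the ring itself matters, which an open-chain acetamido group or a simple amine on the same carbon could help to answer.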